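The compounds below may be only part of what the source reports. "The series", "measured", "known", "first", "only" and "open" are said of these compounds alone.

In a functional assay on HCT-116 cells (Homo sapiens) for cytotoxicity, read by MTT assay, with a stated time of 72 h (on this read-out lower numbers stand for stronger inhibition and higher numbers for weaker inhibition), compound 1 `COc1ncc(-c2ccc3nc(NC(=O)NCCN4CCCCC4)nn3c2)cc1NS(=O)(=O)c1ccc(F)cc1` gives 150 nM and compound 2 `CCN(CC)CCNC(=O)Nc1nc2ccc(-c3cnc(OC)c(NS(=O)(=O)c4ccc(F)cc4F)c3)cn2n1` gives 140 nM, so these two stand level within the usual scatter. They differ in more than one place, so they offer no direct guide to a single change. Compound 3 `CCN(CC)CCNC(=O)Nc1nc2ccc(-c3cnc(OC)c(NS(=O)(=O)c4ccc(C)cc4)c3)cn2n1` departs from compound 2 in one group: 4-methylphenyl in place of 2,4-difluorophenyl on a sulfonyl sulfur, with 4-methylphenyl in place of 2,4-difluorophenyl on a sulfonyl sulfur. No shift beyond the scatter is expected, with only a slight lean towards a higher number, and the estimated change is a 1.4-fold higher number from compound 2 to compound 3 (0.15 log units; within the scatter). For compound 3 the estimated value is 200 nM, within a range of 70 nM to 600 nM.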

Compound 3, half-maximal inhibitory concentration: 170 nM
Estimate against measurement, compound 3: 1.2-fold (0.07 log units) above; the range from low to high includes it.
By their numbers in this assay, from the lowest: compounds 2, 1 and 3 (each within the scatter of the next).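

Within the data shown here, with 4-methylphenyl in place of 2,4-difluorophenyl on a sulfonyl sulfur, this assay shows a 1.2-fold higher number from compound 2 to compound 3 (0.08 log units; within the scatter) as the first single change that can be read here. At this position, then, the two fluorine atoms can give way to one methyl group on the ring with no shift that stands clear of the scatter. Nothing measured here gives a reason for this.

From the compounds shown here alone, whether this tolerance extends to a thiophene ring or a plain methyl group on the sulfonyl sulfur remains open. The amine chains also cannot be compared on their own, since compound 1 differs from compound 2 and compound 3 in more than one place.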